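From phenyl to 4-methoxyphenyl: an expected cytotoxicity step

This account rests on a few compounds, and the source may have more. Where it says the series, first, only, none or still open, it means among the compounds named here.

Compound 1 `COc1ccc(S(=O)(=O)c2nc3ccccc3nc2N2CCCC2)cc1`: > 50000 nM (a limit)
Compound 2 `O=S(=O)(c1ccccc1)c1nc2ccccc2nc1N1CCCC(O)C1`: 1390 nM

For the measured compounds named here, in a functional assay on HCT-116 cells (Homo sapiens) for cytotoxicity, read by MTT assay, with a stated time of 72 h (on this read-out lower numbers stand for stronger inhibition and higher numbers for weaker inhibition), compound 2 gives 1390 nM, the only actual number so far. Compound 3 `COc1ccc(S(=O)(=O)c2nc3ccccc3nc2N2CCCC(O)C2)cc1` has methoxy in place of hydrogen on an aromatic carbon, para to a large group: methoxy in place of hydrogen on an aromatic carbon. Going by the values given here, no measured pair isolates this change. Compound 3 differs elsewhere from compound 1, which also carries 4-methoxyphenyl. Compound 1 gives > 50000 nM, which is a limit, so a modest step toward weaker inhibition is expected in this assay. The expected change is a 1.8-fold higher number from compound 2 to compound 3 (0.25 log units; within the scatter). For compound 3, the estimate is 2500 nM, with an expected range of 700 nM to 15000 nM.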

Compound 3, half-maximal inhibitory concentration: 3520 nM
Beside the measured number, compound 3's estimate is 1.4-fold (0.15 log units) below it; low and high end bracket the measured number.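

In this assay, phenyl to 4-methoxyphenyl now has a measured cost, with the rest of the molecule held constant: a 2.5-fold higher number from compound 2 to compound 3 (0.40 log units; beyond the scatter). With 4-methoxyphenyl kept, 3-hydroxypiperidin-1-yl in place of pyrrolidin-1-yl gives an at least 14-fold lower number from compound 1 to compound 3 (1.15 log units; beyond the scatter), a larger shift than the methoxy step. The value of compound 1 is only a limit: the limit of > 50000 nM in this assay, at which 1 of the 3 values shown sits.

As far as these compounds go, whether fluorine or a dimethylamino group in the same place would shift the number as methoxy does remains open. So does the size of the pyrrolidin-1-yl change when phenyl replaces 4-methoxyphenyl.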